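Compound 1 to compound 3: trifluoromethyl in place of chloro

The source may report more compounds than this note shows. Statements on the series, on what has been measured and on what is new or still open speak of the compounds shown alone.

Within the data shown here, in an ADME assay on cells (Hepatocyte, Mus musculus) for metabolic stability, read by LC-MS, with a stated time of 180 min, tested at 1 uM (a higher number here means faster removal of the compound, a lower number slower removal), compound 1 `CC(C(=O)O)c1nn(Cc2cn3cc(OCC4CC4)c(Cl)cc3n2)c2ccccc2c1=O` gives 76.7 mL/min/kg, the higher of the two numbers measured so far. Compound 2 `O=C(O)Cc1nn(Cc2cn3cc(OCC4CC4)c(Cl)cc3n2)c2ccccc2c1=O` gives 30 mL/min/kg. Among the measured compounds shown here, the one measured step, a 2.6-fold lower number from compound 1 to compound 2 (0.41 log units; beyond the scatter), is modest but beyond the scatter. It replaces methyl with hydrogen on a saturated chain carbon, which is not the place changed next.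

Compound 3 `CC(C(=O)O)c1nn(Cc2cn3cc(OCC4CC4)c(C(F)(F)F)cc3n2)c2ccccc2c1=O` has trifluoromethyl in place of chloro on an aromatic carbon, ortho to a cyclopropylmethoxy group: trifluoromethyl in place of chloro on an aromatic carbon. For the measured compounds named here, no measured pair covers this aromatic carbon, so the size of the step on the chain cannot be carried over. In this assay, no step beyond the scatter is therefore expected, and the estimated step is a 1.2-fold lower number from compound 1 to compound 3 (0.07 log units; within the scatter). For compound 3 the expected clearance is 65 mL/min/kg, with an estimated range of 35 mL/min/kg to 110 mL/min/kg.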

Compound 3, clearance: 71.7 mL/min/kg
Beside the measured number, compound 3's estimate is 1.1-fold (0.04 log units) below it; the measured number falls inside the stated range.
By their numbers in this assay, from the lowest: compound 2; then compounds 3 and 1 (each within the scatter of the next).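

Among these compounds, on the aromatic carbon ortho to a cyclopropylmethoxy group, trifluoromethyl (4 heavy atoms) in place of chloro (1 heavy atom) gives, in this assay, a 1.1-fold lower number from compound 1 to compound 3 (0.03 log units; within the scatter), the first reading at this position. Within this single pair, clearance does not separate the two groups, even with the larger group entering, while the only step beyond the scatter remains the one on the saturated chain carbon, a 2.6-fold lower number from compound 1 to compound 2 (0.41 log units; beyond the scatter). No measured property bears on this result.

From the compounds shown here alone, whether trifluoromethyl and chloro also read alike on the chain without the methyl remains open. So does the reading of a nitrile or a methoxy group on this aromatic carbon, since one exchange cannot define the position's tolerance.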